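Swap at the ring amine nitrogen: working notes

The compounds below may be only part of what the source reports. "The series", "measured", "known", "first", "only" and "open" are said of these compounds alone.

For the measured compounds named here, in a functional assay on Huh-7 cells (Homo sapiens) for antiproliferative activity, read by sulforhodamine B assay, with a stated time of 72 h (on this read-out lower numbers stand for stronger inhibition and higher numbers for weaker inhibition), compound 1 `N#Cc1cccc(COc2ccc(-c3cc(CN4CCN(Cc5ccc(C(F)(F)F)cc5)CC4)no3)cc2)c1` gives 100 nM, the lower of the two numbers measured so far. Going by the values given here, compound 2 `Fc1ccc(COc2ccc(-c3cc(CN4CCN(Cc5ccc(C(F)(F)F)cc5)CC4)no3)cc2)cc1` gives 2000 nM in this assay; the single measured step, a 20-fold higher number from compound 1 to compound 2 (1.30 log units; beyond the scatter), lies at the saturated chain carbon bound to an oxygen on an aromatic ring and does not bear on the change now considered. Compound 3 `N#Cc1cccc(COc2ccc(-c3cc(CN4CCN(c5ccc(C(F)(F)F)cn5)CC4)no3)cc2)c1` differs from compound 1 as follows: 5-(trifluoromethyl)pyridin-2-yl in place of 4-(trifluoromethyl)benzyl on an amine nitrogen in a ring. Among the compounds with values here, with no measured step at the amine nitrogen in a ring, a modest weakening is expected, a 2.5-fold higher number from compound 1 to compound 3 (0.40 log units; beyond the scatter), with wide uncertainty. Compound 3 is estimated at 250 nM, range 40 nM to 1600 nM.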

Compound 3, half-maximal inhibitory concentration: 1700 nM
Beside the measured number, compound 3's estimate is 6.8-fold (0.83 log units) below it, outside the stated range (above it).
By their numbers in this assay, from the lowest: compound 1; then compounds 3 and 2 (each within the scatter of the next).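

The amine nitrogen in the ring is a sensitive position in this assay: the change gives a 17-fold higher number from compound 1 to compound 3 (1.23 log units; beyond the scatter). This single step replaces 4-(trifluoromethyl)benzyl with 5-(trifluoromethyl)pyridin-2-yl, so the ring nitrogen and the heavy-atom count change together while the trifluoromethyl group remains. No available evidence bears on the reason for the step.

From the compounds shown here alone, it remains open whether the ring nitrogen or the rest of the exchange accounts for the step. A 4-(trifluoromethyl)phenyl group or a (trifluoromethyl)pyridinylmethyl group on the same amine nitrogen would separate these two changes.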